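This account rests on a few compounds, and the source may have more. Where it says the series, first, only, none or still open, it means among the compounds named here.

Compound 1, `Cc1c(OCCCCOc2ccc(C(=O)O)cc2)ccc(C(=O)CC2CCCC2)c1O`, is measured in an assay on HEK293 cells for positive allosteric modulation of metabotropic glutamate receptor 2 (Rattus norvegicus), read by thallium flux, with a stated time of 2.5 min (a higher number here means a larger maximal response, a lower number a smaller maximal response), where compound 1 gives 82.6%. Among the three compounds measured, compound 1 stands second highest. Compound 3, `Cc1c(OCCCCOCOc2ccc(C(=O)O)cc2)ccc(C(=O)CC2CCCC2)c1O`, gives 95.4%, and the step of a number 12.8 percentage points higher from compound 1 to compound 3 (beyond the scatter) is modest. Compound 2, `COC(=O)c1ccc(OCCCCOc2ccc(C(=O)CC3CCCC3)c(O)c2C)cc1`, gives 12.2%, and the step of a number 70.4 percentage points lower from compound 1 to compound 2 (beyond the scatter) is large. Between compound 2 and compound 3 the step of a number 83.2 percentage points higher from compound 2 to compound 3 (beyond the scatter) is likewise large.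

Compound 4, `Cc1c(OCCCCOc2ccc(C(=O)O)cc2)ccc(C(=O)CC2CCCC2)c1C`, differs from compound 1 by methyl in place of hydroxy on an aromatic carbon. Among the compounds with values here, both measured steps alter the group at the far end of the chain, where the carboxylic acid is either turned into its methyl ester or moved outward by a (4-carboxyphenoxy)methyl unit; neither touches the hydroxy on the aromatic ring of the shared core, so no measured step bears directly on the change to compound 4. The large size of the step from compound 1 to compound 2 shows that a single small change can move the response far in this assay, so a wide range is expected. For compound 4 a response of 60% is estimated, within 20% to 95%, which means an expected step of a number 22.6 percentage points lower from compound 1 to compound 4 (beyond the scatter).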

Compound 4, largest response reached (reported as percent of maximum), in percent of the reference or control that the assay uses: 16.2%
The estimate for compound 4 lay 43.8 percentage points above the measured number; measured number below the stated range.
By their numbers in this assay, from the lowest: compounds 2 and 4 (each within the scatter of the next); then compound 1; then compound 3.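

In this assay, replacing hydroxy with methyl on the aromatic carbon ortho to a (cyclopentylmethyl)carbonyl group gives the step of a number 66.4 percentage points lower from compound 1 to compound 4 (beyond the scatter), which is large. The earlier steps shown here changed only the far end of the chain, whereas this one shows that the maximal response also depends on this position of the shared core: compound 4 keeps the carboxylic acid of compound 1, yet that group alone does not preserve the response. No available measurement explains why this exchange, which removes the hydrogen-bond donor and acceptor of the hydroxy, has so large an effect.

The compounds shown carry only hydroxy or methyl at this position, so they leave open how a methoxy, an amine or a fluorine there would behave, and thus whether the response depends on the hydroxy specifically. They also leave open whether the same exchange would have a step of similar size on the (4-carboxyphenoxy)methyl chain end of compound 3.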